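A Ring Nitrogen Trades Its Aryl Group for Pyridinyl

This account rests on a few compounds, and the source may have more. Where it says the series, first, only, none or still open, it means among the compounds named here.

Compound 1 `Nc1ccccc1NC(=O)c1ccc(CSC(=S)N2CCN(Cc3ccccn3)CC2)cc1`: 23.4%
Compound 2 `Nc1ccccc1NC(=O)c1ccc(CSC(=S)N2CCN(c3ccc(F)cc3)CC2)cc1`: 18.8%
Compound 3 `Cc1ccc(N2CCN(C(=S)SCc3ccc(C(=O)Nc4ccccc4N)cc3)CC2)cc1`: 33.4%

In a functional assay on MGC-803 cells (Homo sapiens) for antiproliferative activity, read by CCK-8 assay, with a stated time of 72 h, tested at 2 uM (a lower number here means a weaker effect, a higher number a stronger effect of the compound at the concentration tested), compound 3 gives the highest of the three numbers. Its nearest neighbour is compound 1, as the step of a number 10 percentage points higher from compound 1 to compound 3 (within the scatter) stays within the scatter; the furthest is compound 2, since a number 14.6 percentage points higher from compound 2 to compound 3 (beyond the scatter) lies beyond it. Compound 4 `Nc1ccccc1NC(=O)c1ccc(CSC(=S)N2CCN(c3ccncc3)CC2)cc1` is not yet measured. It differs from compound 3 in one place: pyridin-4-yl in place of 4-methylphenyl on an amine nitrogen in a ring. Within the data shown here, the steps that bear on this change are a number 10 percentage points higher from compound 1 to compound 3 (within the scatter) and a number 14.6 percentage points higher from compound 2 to compound 3 (beyond the scatter), both modest and both ending at compound 3, which holds the highest value. A move away from the 4-methylphenyl group is therefore expected to lower the number, and the estimated step is a number 10.4 percentage points lower from compound 3 to compound 4 (beyond the scatter). Compound 4 is expected at 23%, within 12% to 34%.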

Compound 4, a percentage reported as inhibition, at one concentration (the size of the read-out at that concentration, not a potency): 64.8%
Beside the measured number, compound 4's estimate is 41.8 percentage points below it, outside the stated range (above it).
By their numbers in this assay, from the lowest: compounds 2, 1 and 3 (each within the scatter of the next, the first and the last beyond it); then compound 4.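

On the amine nitrogen in the ring, the change to pyridin-4-yl gives a number 31.4 percentage points higher from compound 3 to compound 4 (beyond the scatter) and a number 46 percentage points higher from compound 2 to compound 4 (beyond the scatter) in this assay, both far larger than the step between the two substituted phenyl groups. Compound 1 also carries a pyridine ring, yet a number 41.4 percentage points higher from compound 1 to compound 4 (beyond the scatter) shows that such a ring alone, when held on a methyl link, does not bring this level. Nothing available explains the gain. Going by these compounds, whether pyridin-3-yl or pyridin-2-yl set directly on the ring nitrogen keeps the gain remains open, and so does the effect of a pyrimidin-4-yl group.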